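The source may hold more compounds than are shown below. What is called first, only, known or untested is meant among the compounds shown, and "the series" means these compounds.

Compound 1 `N#Cc1c(NN)nc(SCc2nc3ccccc3[nH]2)nc1-c1ccccc1` gives 2.55 nM
Compound 2 `CNc1nc(SCc2nc3ccccc3[nH]2)nc(-c2ccccc2)c1C#N` gives 3.7 nM
Compound 3 `N#Cc1c(-c2ccccc2)nc(SCc2nc3ccccc3[nH]2)nc1N1CCNCC1` gives 5.81 nM

In a functional assay on RKOp27 cells (Homo sapiens) for cytotoxicity, read by MTT assay, with a stated time of 3 days (a higher number here means a weaker inhibitor, a lower number a stronger inhibitor), compound 3 stands apart only from compound 1, with a 2.3-fold higher number from compound 1 to compound 3 (0.36 log units; beyond the scatter) as the step, while a 1.6-fold higher number from compound 2 to compound 3 (0.20 log units; within the scatter) is how it relates to compound 2. Compound 4 `CN1CCN(c2nc(SCc3nc4ccccc4[nH]3)nc(-c3ccccc3)c2C#N)CC1` differs from compound 3 in one place: methyl in place of hydrogen on an amine nitrogen in a ring. For the measured compounds named here, no measured step tests this methyl directly. Going by the values given here, replacing whole groups gave only the steps above and a 1.5-fold higher number from compound 1 to compound 2 (0.16 log units; within the scatter), so a single methyl is expected to cause no step beyond the scatter in this assay. The expected step is a 1.0-fold higher number from compound 3 to compound 4 (0.01 log units; within the scatter) in size. Compound 4 is therefore estimated at 6 nM, with an expected range from 2.5 nM to 14 nM.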

Compound 4, half-maximal inhibitory concentration: 5.4 nM
Compound 4: middle estimate off by 1.1-fold (0.05 log units), on the high side, within the range that was stated.
By their numbers in this assay, from the lowest: compounds 1, 2, 4 and 3 (each within the scatter of the next, the first and the last beyond it).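

In this assay the amine nitrogen in the ring accepts a methyl with no readable change (a 1.1-fold lower number from compound 3 to compound 4 (0.03 log units; within the scatter)), so the hydrogen there is not needed to hold the number. The 4-methylpiperazin-1-yl group also stays level with methylamino (a 1.5-fold higher number from compound 2 to compound 4 (0.16 log units; within the scatter)), and, like piperazin-1-yl, it stands apart only from aminoamino (a 2.1-fold higher number from compound 1 to compound 4 (0.33 log units; beyond the scatter)). Nothing available gives a cause for these steps. Still open, from the compounds shown here alone, is whether a longer chain or an acetyl on that nitrogen would hold the number, and whether morpholin-4-yl could replace the whole ring.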